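Thiourea to cyanoguanidine on a lengthened chain

The compounds below may be only part of what the source reports. "The series", "measured", "known", "first", "only" and "open" are said of these compounds alone.

The measured compounds, in a functional assay on the whole organism (stomach) with Rattus norvegicus as the target; on this read-out higher numbers stand for an effect only at larger amounts of compound and lower numbers for an effect already at smaller amounts:
Compound 1, `N#CNC(=N)NCCCCCn1nc(-c2ccccc2)ccc1=O`, reaches only the assay limit of > 100 mg/kg.
Compound 2, `C/N=C(\S)NCCCCCn1nc(-c2ccccc2)ccc1=O`, gives 35.3 mg/kg.
Compound 3, `CC/N=C(\S)NCCCCCn1nc(-c2ccccc2)ccc1=O`, gives 51.8 mg/kg.

Compound 3 and compound 2 differ by a 1.5-fold higher number from compound 2 to compound 3 (0.17 log units; within the scatter), so the two sit together within the scatter. The value for compound 1 is a limit only (the limit of > 100 mg/kg in this assay, at which 1 of the 3 values shown sits).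

Compound 4, `C/N=C(/NC#N)NCCCCCCn1nc(-c2ccccc2)ccc1=O`, differs from compound 3 by a group of 8 heavy atoms (4 carbon, 4 nitrogen; no ring) in place of a group of 6 heavy atoms (3 carbon, 2 nitrogen, 1 sulfur; no ring), on a saturated chain carbon, five bonds along the chain from an aromatic nitrogen. Within the data shown here, no measured step copies this change, since the chain also grows. The nearest evidence runs the other way: replacing a cyanoguanidine by a thiourea gave an at least 2.8-fold lower number from compound 1 to compound 2 (0.45 log units; beyond the scatter) and an at least 1.9-fold lower number from compound 1 to compound 3 (0.28 log units; that floor lies within the scatter). Returning to a cyanoguanidine is therefore expected to raise the number in this assay, by an estimated 2.3-fold higher number from compound 3 to compound 4 (0.36 log units; beyond the scatter). Compound 4 is thus expected to give about 120 mg/kg, between 40 mg/kg and 400 mg/kg, with a fair chance that only a limit is reported.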

Compound 4, dose for half-maximal effect: > 100 mg/kg
Compound 4: a limit, no number (the forecaster's own chance of this, stated with the estimate: 50%); the middle value does not contradict the limit.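

Compound 4 joins compound 1 as a second cyanoguanidine at the limit, although it also has a longer chain and a further methyl group; in this assay, compound 4 gives > 100 mg/kg, which is a limit and not a number. Against the two thioureas, the change gives an at least 2.8-fold higher number from compound 2 to compound 4 (0.45 log units; beyond the scatter) and an at least 1.9-fold higher number from compound 3 to compound 4 (0.28 log units; that floor lies within the scatter), so only the first step is sure to clear the scatter. The step between the two cyanoguanidines cannot be read: the limit of > 100 mg/kg in this assay, at which 2 of the 4 values shown sit.

The cyanoguanidine and the longer chain changed together, so the compounds shown do not separate their contributions, and how far either limit compound lies from a measurable dose remains unknown. Going by these compounds, it also remains open how a thiourea on this longer chain, or an amine or a carboxylic acid in the same place, would read out.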